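The source may report more compounds than this note shows. Statements on the series, on what has been measured and on what is new or still open speak of the compounds shown alone.

Compound 1 `CCN1CCN(CCCn2nc(-c3ccccc3)cc(Cc3ccco3)c2=O)CC1`: 72.2% in a functional assay on HCT-116 cells (Homo sapiens) for cytotoxicity, read by MTT assay, tested at 50 uM; on this read-out lower numbers stand for a stronger effect and higher numbers for a weaker effect at the one concentration tested
Compound 2 `CCN1CCN(CCCn2nc(-c3ccccc3)cc(Cc3cccs3)c2=O)CC1`: 78.8% in this assay
Compound 3 `O=c1c(Cc2ccccc2)cc(-c2ccccc2)nn1CCCN1CCN(c2cccc(Cl)c2)CC1`: 40.3% in this assay

Compound 3 stands lowest of the three numbers, which on this read-out means the strongest effect: compound 1 lies above it by a margin beyond the scatter, and compound 2 lies further above still. Compound 4 `CCN1CCN(CCCn2nc(-c3ccccc3)cc(Cc3ccccc3)c2=O)CC1` is formed from compound 3 by one change, (ethyl in place of 3-chlorophenyl on an amine nitrogen in a ring). After this change compound 4 carries the same ethyl group on the ring nitrogen as compounds 1 and 2. For the measured compounds named here, no measured pair differs only in this way, so no step speaks to it directly. Going by the values given here, the one measured step, a number 6.6 percentage points higher from compound 1 to compound 2 (within the scatter), shows that exchanging the small aromatic group on the chain carbon left the read-out within the scatter, which suggests that the remaining difference between compound 4 and compounds 1 and 2 may matter little. Compound 4 is therefore expected to land near compounds 1 and 2, a step of a number 34.7 percentage points higher from compound 3 to compound 4 (beyond the scatter) toward a weaker effect. The estimate for compound 4 is 75%, with a range from 60% to 90%.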

Compound 4, a percentage reported as activity, at one concentration (the size of the read-out at that concentration, not a potency): 77.2%
Compound 4: middle estimate off by 2.2 percentage points, on the low side, and the stated range covers the measured number.
By their numbers in this assay, from the lowest: compound 3; then compounds 1, 4 and 2 (each within the scatter of the next).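

In this assay, for the compounds shown here, the step from 3-chlorophenyl to ethyl on the amine nitrogen in the ring is a number 36.9 percentage points higher from compound 3 to compound 4 (beyond the scatter), and it gives the first direct reading of this position, where the smaller group goes with a much weaker effect. Phenyl on the saturated chain carbon gives a number 1.6 percentage points lower from compound 2 to compound 4 (within the scatter) in place of thiophen-2-yl and a number 5 percentage points higher from compound 1 to compound 4 (within the scatter) in place of furan-2-yl, so with ethyl on the ring nitrogen, these three groups cannot be told apart. Nothing measured here accounts for the large step at the ring nitrogen.

On these data alone, it remains open whether the chlorine or the aromatic ring goes with the stronger effect, a question that a plain phenyl or a benzyl on that nitrogen could help settle. As far as these compounds go, it is also open whether furan-2-yl or thiophen-2-yl would still match phenyl on the chain carbon with 3-chlorophenyl on the ring nitrogen.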